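Swapping a Pyridine Arm for Cyclohexyl on a Caged Amine

The source may hold more compounds than are shown below. What is called first, only, known or untested is meant among the compounds shown, and "the series" means these compounds.

Of the compounds shown here, two sharing a caged core have been tested in an assay on brain for displacement of a labelled ligand from Sigma non-opioid intracellular receptor 1 (Rattus norvegicus); on this read-out lower numbers stand for stronger inhibition and higher numbers for weaker inhibition. Compound 1 `C1CCC(CN[C@H]2C3C4CC5C6C4CC3C6C52)CC1` gives 4 nM, while compound 2 `CN(Cc1cccnc1)[C@H]1C2C3CC4C5C3CC2C5C41` gives 970 nM, the higher of the two numbers and far apart from compound 1. Compound 3 `CN(CC1CCCCC1)[C@H]1C2C3CC4C5C3CC2C5C41` has not yet been measured in this assay. It differs from compound 2 by cyclohexyl in place of pyridin-3-yl on a saturated chain carbon bound to an amine nitrogen. For the measured compounds named here, no measured pair shows this exact change, so the expectation leans on compound 1, whose 4 nM also belongs to an amine carrying a cyclohexyl group. The step from compound 2 to compound 3 is expected to be large and towards a lower number, a 49-fold lower number from compound 2 to compound 3 (1.69 log units; beyond the scatter). Compound 3 is estimated at 20 nM, within a range from 4 nM to 120 nM.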

Compound 3, inhibition constant: 15 nM
Compound 3: middle estimate off by 1.3-fold (0.12 log units), on the high side, within the range that was stated.
By their numbers in this assay, from the lowest: compound 1; then compound 3; then compound 2.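

Cyclohexyl in place of pyridin-3-yl gives a 65-fold lower number from compound 2 to compound 3 (1.81 log units; beyond the scatter) in this assay, so the ring held on this saturated chain carbon bound to an amine nitrogen matters strongly for the read-out. Methyl in place of hydrogen on the amine nitrogen gives a much smaller step, a 3.8-fold higher number from compound 1 to compound 3 (0.57 log units; beyond the scatter), though it still lies beyond the usual scatter. Nothing here explains why either change has the effect it does.

Phenyl, an aromatic ring of carbon only, could show whether the large step follows the ring nitrogen or the aromatic ring, and that remains open.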